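Moving a hydroxy group: from compound 2 to compound 3

The compounds below may be only part of what the source reports. "The series", "measured", "known", "first", "only" and "open" are said of these compounds alone.

Compound 1 `Brc1ccc2[nH]cc(C(c3ccccc3)c3c[nH]c4ccc(Br)cc34)c2c1`: 7500 nM
Compound 2 `Oc1ccc(C(c2c[nH]c3ccc(Br)cc23)c2c[nH]c3ccc(Br)cc23)cc1`: 9000 nM

Both compounds were tested in a functional assay on A549 cells (Homo sapiens) for inhibition, read by MTT assay, with a stated time of 48 h; a lower number here means a stronger inhibitor, a higher number a weaker inhibitor. Going by the values given here, compound 2 gives 9000 nM, and its only neighbour on the scale is compound 1, which gives 7500 nM. These two numbers lie within the normal scatter of each other, so they cannot be told apart.

The next compound, compound 3 `Oc1cccc(C(c2c[nH]c3ccc(Br)cc23)c2c[nH]c3ccc(Br)cc23)c1`, has the same atoms as compound 2, joined differently: 3-hydroxyphenyl in place of 4-hydroxyphenyl on a saturated chain carbon bound to two aromatic carbons. Among the compounds with values here, only one measured step bears on this change, namely hydroxy in place of hydrogen on an aromatic carbon, which gave a 1.2-fold higher number from compound 1 to compound 2 (0.08 log units; within the scatter). That step adds a hydroxy group rather than relocating one, so it is only indirect evidence. Within the data shown here, no measured pair tests the swap itself.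

Among the measured compounds shown here, with a 1.2-fold higher number from compound 1 to compound 2 (0.08 log units; within the scatter) as the only guide, no shift beyond the scatter is expected in this assay, and no direction can be favoured. For the measured compounds named here, the expected change is a 1.1-fold lower number from compound 2 to compound 3 (0.02 log units; within the scatter), which is no real step. For compound 3 the estimated value is 8500 nM, with an expected range from 4000 nM to 18000 nM.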

Compound 3, half-maximal inhibitory concentration: 8000 nM
Compound 3: middle estimate off by 1.1-fold (0.03 log units), on the high side, within the range that was stated.
By their numbers in this assay, from the lowest: compounds 1, 3 and 2 (each within the scatter of the next).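

The new compound adds a second position to the comparison. In this assay, going by these compounds alone, moving the group, with 3-hydroxyphenyl in place of 4-hydroxyphenyl on a saturated chain carbon bound to two aromatic carbons, produces no step that can be told from scatter (a 1.1-fold lower number from compound 2 to compound 3 (0.05 log units; within the scatter)). The hydroxy group in its new place likewise makes no readable difference from hydrogen on an aromatic carbon (a 1.1-fold higher number from compound 1 to compound 3 (0.03 log units; within the scatter)), so compounds 1, 2 and 3 cannot be separated, and neither the presence of this hydroxy group nor which of these two places it occupies shows any effect here. No independent measurement is available to say anything further about this result.

On these data alone, whether an amine or a carboxylic acid on this ring, or a longer chain carrying the hydroxy group, would move the number beyond the scatter remains open. Also open, as far as these compounds go, is whether this ring tolerates change in general, as these three compounds vary only by one hydroxy group and its place.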